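Methylsulfonyl in place of methanesulfonamido: what to expect

The compounds below may be only part of what the source reports. "The series", "measured", "known", "first", "only" and "open" are said of these compounds alone.

Compound 1 `O=C(Nc1cccc([N+](=O)[O-])c1)C1CCCN(C(=O)c2cc(C(F)(F)F)cc(C(F)(F)F)c2)C1`: 9%
Compound 2 `CS(=O)(=O)Nc1cccc(C(=O)N2CCCC(C(=O)Nc3ccc(Cl)cc3)C2)c1`: 3%
Compound 3 `O=C(c1ccccc1)c1cccc(NC(=O)C2CCCN(C(=O)c3cc(C(F)(F)F)cc(C(F)(F)F)c3)C2)c1`: 0%

All three compounds were tested in an ADME assay on PC-3 cells (Homo sapiens) for cytotoxicity, read by WST assay, tested at 100 uM (a higher number here means more inhibition at the concentration tested (going by the name of the read-out), a lower number less inhibition), and all give low numbers. Compound 2 stands second highest of the three; its nearest neighbour is compound 3 and its furthest is compound 1, and both gaps lie within the scatter. Among the compounds with values here, the only measured single-point step, a number 9 percentage points lower from compound 1 to compound 3 (within the scatter), concerns a different position and is itself within the scatter. Compound 4 `CS(=O)(=O)c1cccc(C(=O)N2CCCC(C(=O)Nc3ccc(Cl)cc3)C2)c1` differs from compound 2 by methylsulfonyl in place of methanesulfonamido on an aromatic carbon. Within the data shown here, no measured step bears on this change, and with every number so far near the floor, no step beyond the scatter is expected: a number 1 percentage points higher from compound 2 to compound 4 (within the scatter). Compound 4 is therefore estimated at 4%, ranging from 0% to 15%.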

Compound 4, a percentage reported as inhibition, at one concentration (the size of the read-out at that concentration, not a potency): 2%
Compound 4: the middle estimate sits 2 percentage points above what was measured; measured number inside the range.
By their numbers in this assay, from the lowest: compounds 3, 4, 2 and 1 (each within the scatter of the next).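

In this assay, the first step read at this position is a number 1 percentage points lower from compound 2 to compound 4 (within the scatter), so taking away the nitrogen and its hydrogen-bond donor leaves the number where it was, within the scatter. With both compounds near the floor at this single concentration, the pair shows no sign that this aromatic carbon governs the read-out. Nothing on hand offers an explanation for this result. As far as these compounds go, whether an amine or a carboxylic acid on this aromatic carbon would move the number beyond the scatter stays open.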